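Cytotoxicity limits and a new thiazole ether

The source may hold more compounds than are shown below. What is called first, only, known or untested is meant among the compounds shown, and "the series" means these compounds.

Measured in an ADME assay on MT4 cells (Homo sapiens) for cytotoxicity; a lower number here means that less compound is tolerated, a higher number that more compound is tolerated:
- Compound 1 `COC(=O)N[C@H](C(=O)NN(CCC[C@@](O)(Cc1ccccc1)C(=O)N[C@H]1c2ccccc2C[C@H]1O)Cc1ccccc1)C(C)(C)C`: > 10000 nM (a limit)
- Compound 2 `COC(=O)N[C@H](C(=O)NN(CCC[C@@](O)(Cc1ccccc1)C(=O)N[C@H]1c2ccccc2C[C@H]1O)Cc1ccc(C#N)cc1)C(C)(C)C`: > 10000 nM (a limit)
- Compound 3 `COC(=O)N[C@H](C(=O)NN(CCC[C@@](O)(Cc1ccccc1)C(=O)N[C@H]1c2ccccc2C[C@H]1O)Cc1ccc(-c2noc(C)n2)cc1)C(C)(C)C`: > 10000 nM (a limit)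

None of these entries is an exact number. Together they make up (the limit of > 10000 nM in this assay, at which 3 of the 3 values shown sit). Compound 3 therefore has no exact position among the three, and it cannot be ranked against compound 1 or compound 2.

The next compound, compound 4 `COC(=O)N[C@H](C(=O)NN(CCC[C@@](O)(Cc1ccccc1)C(=O)N[C@H]1c2ccccc2C[C@H]1O)Cc1ccc(OCc2cnc(Cl)s2)cc1)C(C)(C)C`, carries (2-chloro-1,3-thiazol-5-yl)methoxy in place of 5-methyl-1,2,4-oxadiazol-3-yl on an aromatic carbon.

For the measured compounds named here, three measured steps bear on this change, since all involve the same place on the ring. Going by the values given here, the first is a step that the two limits leave unreadable from compound 1 to compound 2. The second is a step that the two limits leave unreadable from compound 1 to compound 3. The third is a step that the two limits leave unreadable from compound 2 to compound 3. None of them has a size that can be read, so they offer no measured effect to carry over, and no direction can be predicted in this assay.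

The expected outcome is a step that the limit leaves unreadable from compound 3 to compound 4, with no step beyond the usual scatter foreseen. Another reported limit is the most likely result. Compound 4 is estimated at about 12000 nM, with an expected range from 5000 nM to 30000 nM.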

Compound 4, half-maximal cytotoxic concentration: > 10000 nM
Compound 4: only a limit was reported; the forecaster's own chance of this, stated with the estimate: 75%; the middle value is on the limit's open side.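

In this assay compound 4 gives > 10000 nM, which is a limit and not an exact number. For the compounds shown here, no step from compound 1, compound 2 or compound 3 to compound 4 can be read, and the four compounds end up together: the limit of > 10000 nM in this assay, at which 4 of the 4 values shown sit. On these data alone, the exact half-maximal cytotoxic concentration of each compound, and any difference among the four in this assay, stay open.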